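The source may report more compounds than this note shows. Statements on the series, on what has been measured and on what is new or still open speak of the compounds shown alone.

Measured so far: compound 1 `NS(=O)(=O)c1ccc(Nc2nccc(-c3cccnc3)n2)cc1` gives 200 nM in a functional assay for inhibition, with Homo sapiens as the target; a higher number here means a weaker inhibitor, a lower number a stronger inhibitor; compound 2 `NS(=O)(=O)c1ccc(Nc2nccc(-c3ccncc3)n2)cc1` gives 5100 nM; compound 3 `Cc1cc(C)cc(Nc2nccc(-c3cccnc3)n2)c1` gives 800 nM.

Compound 2 stands highest of the three numbers in this assay, meaning it is the weakest inhibitor shown. Within the data shown here, the only step between measured compounds, a 26-fold higher number from compound 1 to compound 2 (1.41 log units; beyond the scatter), concerns a different part of the molecule and so does not bear on the change now made. Compound 4 `Cc1cn(-c2ccc(Nc3nccc(-c4ccncc4)n3)cc2)cn1` differs from compound 2 by 4-methyl-1H-imidazol-1-yl in place of sulfamoyl on an aromatic carbon. Among the measured compounds shown here, no measured step covers this exchange; compound 1 and compound 3, which differ at the same place, only show that their values lie apart. The step from compound 2 to compound 4 is therefore expected to be modest and of uncertain direction, a 1.3-fold lower number from compound 2 to compound 4 (0.11 log units; within the scatter). Compound 4 is estimated at 4000 nM, within 1000 nM to 20000 nM.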

Compound 4, half-maximal inhibitory concentration: > 3000 nM
Compound 4 was reported as a limit; the forecaster's own chance of this, stated with the estimate: 10%; the middle value lies beyond the limit too.
By their numbers in this assay, from the lowest: compound 1; then compound 3; then compound 2.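

In this assay compound 4 gives > 3000 nM which is a limit and not a number, so the step from compound 2 to compound 4 cannot be read. The compounds shown leave open whether 4-methyl-1H-imidazol-1-yl in place of sulfamoyl strengthens or weakens inhibition.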